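Swapping Iodo for Fluoro: Expected Cytotoxicity of Compound 4

A few compounds are considered here, and "the series" means these few. Any claim that something is new, unique, unknown or untested is made for them only; others in the source may bear on it.

Measured so far in an ADME assay on L6 cells (Rattus norvegicus) for cytotoxicity, read by resazurin assay, with a stated time of 72 h; on this read-out higher numbers stand for weaker inhibition and lower numbers for stronger inhibition:
Compound 1, `O=C1[C@H]2N=NN(Cc3nc(-c4ccc([N+](=O)[O-])cc4)no3)[C@H]2C(=O)N1c1ccccc1`, gives > 100 ug/mL; this is a limit of the assay, not a number.
Compound 2, `O=C1[C@H]2N=NN(Cc3nc(-c4ccc(Cl)cc4)no3)[C@H]2C(=O)N1c1ccccc1`, gives 49.5 ug/mL.
Compound 3, `O=C1[C@H]2N=NN(Cc3nc(-c4ccc(I)cc4)no3)[C@H]2C(=O)N1c1ccccc1`, gives 48.6 ug/mL.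

Among the two actual numbers, compound 3 is separated from the other by a 1.0-fold lower number from compound 2 to compound 3 (0.01 log units; within the scatter), a gap within the scatter, so the two cannot be told apart. Compound 1 sits at the limit of > 100 ug/mL in this assay, at which 1 of the 3 values shown sits. The steps of an at least 2.0-fold lower number from compound 1 to compound 2 (0.30 log units; that floor lies within the scatter) and an at least 2.0-fold lower number from compound 1 to compound 3 (0.31 log units; beyond the scatter) are therefore only floors: halogens gave lower numbers than nitro, but how much lower is not known.

Compound 4, `O=C1[C@H]2N=NN(Cc3nc(-c4ccc(F)cc4)no3)[C@H]2C(=O)N1c1ccccc1`, has not yet been measured. It differs from compound 3 by fluoro in place of iodo on an aromatic carbon. The step that bears most directly on this change is a 1.0-fold lower number from compound 2 to compound 3 (0.01 log units; within the scatter), where one halogen replaced another with no shift beyond the scatter. Given a 1.0-fold lower number from compound 2 to compound 3 (0.01 log units; within the scatter), the expected step is a 1.2-fold higher number from compound 3 to compound 4 (0.09 log units; within the scatter), nothing beyond the scatter in either direction, though a drift toward the higher numbers seen with compound 1 cannot be ruled out. Compound 4 is therefore estimated at 60 ug/mL, with a range from 30 ug/mL to 100 ug/mL.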

Compound 4, half-maximal inhibitory concentration: > 100 ug/mL
Compound 4 gave a limit, no number; the forecaster's own chance of this, stated with the estimate: 25%; middle value at least 1.6-fold (0.22 log units) from the limit.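

In this assay, the change from 4-iodophenyl to 4-fluorophenyl gives an at least 2.0-fold higher number from compound 3 to compound 4 (0.31 log units; beyond the scatter), so trading one halogen for another at this position is not always silent, although chloro and iodo could not be told apart. The change from chloro to fluoro gives an at least 2.0-fold higher number from compound 2 to compound 4 (0.30 log units; that floor lies within the scatter), which is only a floor and on its own cannot be separated from the scatter. Compound 4 gives a limit, not a number, and shares it with compound 1, so the step between those two cannot be read, and the earlier observation that halogens gave lower numbers than nitro now holds for chloro and iodo but not for fluoro: the limit of > 100 ug/mL in this assay, at which 2 of the 4 values shown sit.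

As far as these compounds go, neither limit gives a number, so whether compound 1 and compound 4 truly match stays open. Also open, from the compounds shown here alone, is where other groups at this position would fall, such as bromo, an amine, a carboxylic acid or a methoxy group, and whether any of them would sit with compound 3 or with compound 4.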